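This account rests on a few compounds, and the source may have more. Where it says the series, first, only, none or still open, it means among the compounds named here.

Three compounds share one core and differ only in the aryl group carried on a nitrogen on an aromatic ring. Compound 1 `COc1cc2ncnc(Nc3ccc(F)c(Cl)c3)c2cc1OCCCCC(=O)Nc1ccc(S(N)(=O)=O)cc1` carries a 3-chloro-4-fluorophenyl there, and in a functional assay on A549 cells (Homo sapiens) for antiproliferative activity, read by MTT assay, with a stated time of 72 h (a lower number here means a stronger inhibitor, a higher number a weaker inhibitor), compound 1 gives 15500 nM. Compound 2 `C#Cc1cccc(Nc2ncnc3cc(OC)c(OCCCCC(=O)Nc4ccc(S(N)(=O)=O)cc4)cc23)c1` carries a 3-ethynylphenyl, and in this assay compound 2 gives 7720 nM; the step is a 2.0-fold lower number from compound 1 to compound 2 (0.30 log units; within the scatter). Compound 3 `COc1cc2ncnc(Nc3ccc(Cl)cc3)c2cc1OCCCCC(=O)Nc1ccc(S(N)(=O)=O)cc1` carries a 4-chlorophenyl. For compound 3 this assay reports only a limit, > 40000 nM (the limit of > 40000 nM in this assay, at which 1 of the 3 values shown sits). Compound 3 thus stands as the weakest inhibitor of the three, since an at least 2.5-fold higher number from compound 1 to compound 3 (0.41 log units; beyond the scatter) and an at least 5.1-fold higher number from compound 2 to compound 3 (0.71 log units; beyond the scatter).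

Compound 4 `COc1ccc(Nc2ncnc3cc(OC)c(OCCCCC(=O)Nc4ccc(S(N)(=O)=O)cc4)cc23)cc1OC` is not yet measured. It differs from compound 3 in one place: 3,4-dimethoxyphenyl in place of 4-chlorophenyl on a nitrogen on an aromatic ring. Both measured steps that bear on this position are swaps towards 4-chlorophenyl and both raised the number beyond the scatter; none shows a swap away from it, and none brings in a 3,4-dimethoxyphenyl. The value of compound 3 is a limit, so the size and direction of the step in this assay cannot be read from the numbers. Compound 4 is expected to stay near that limit, the estimated step being a number no higher from compound 3 to compound 4 (the limit leaves the size open). Compound 4 is estimated at 40000 nM, between 10000 nM and 150000 nM.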

Compound 4, half-maximal inhibitory concentration: > 40000 nM
Compound 4: only a limit was reported; the forecaster's own chance of this, stated with the estimate: 60%; the middle value lies on the limit itself.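

Compound 4 joins compound 3 at the limit of this assay, so a second aryl group on this nitrogen gives no measurable value in the tested range: the limit of > 40000 nM in this assay, at which 2 of the 4 values shown sit. Measured against the two compounds with readable values, the 3,4-dimethoxyphenyl gives an at least 5.1-fold higher number from compound 2 to compound 4 (0.71 log units; beyond the scatter) and an at least 2.5-fold higher number from compound 1 to compound 4 (0.41 log units; beyond the scatter). It also has the same pattern of substitution as the 3-chloro-4-fluorophenyl of compound 1, so that pattern alone does not bring a compound below the limit, and the step between the two compounds at the limit cannot be read, leaving the 3,4-dimethoxyphenyl and the 4-chlorophenyl unordered.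

On these data alone, how far compound 3 and compound 4 lie beyond the limit remains open, as does whether a 3-methoxyphenyl or a 3-aminophenyl on this nitrogen would give a readable value. As far as these compounds go, all four compounds also keep the same chain and the same sulfonamide end, so the effect of a shorter chain, or of a carboxylic acid in place of the sulfonamide, on these aryl differences is unknown.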